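Acetylating a Second Hydroxy Group of Compound 1

This account rests on a few compounds, and the source may have more. Where it says the series, first, only, none or still open, it means among the compounds named here.

In a functional assay on HepG2 cells (Homo sapiens) for cytotoxicity, read by XTT assay (a lower number here means a stronger inhibitor, a higher number a weaker inhibitor), compound 1 (`C/C(=C\[C@@H](O)C/C(C)=C/CCc1ccoc1)CC[C@@H](O)[C@]1(C)CCC(=O)O1`) gives 1000 nM as its reading. Compound 3 (`CC(=O)O[C@H](CC/C(C)=C/[C@@H](O)C/C(C)=C/CCc1ccoc1)[C@]1(C)CCC(=O)O1`) gives 500 nM and so lies within the scatter of compound 1. Compound 2 (`C/C(=C\[C@@H](O)C/C(C)=C/CCCC(=O)CO)CC[C@@H](O)[C@]1(C)CCC(=O)O1`) gives > 20000 nM as its reading, and this is a limit of the assay and not a number. Compound 1 therefore stands level with compound 3 within the scatter, while compound 2 is separated from it by a large step.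

Compound 4 (`CC(=O)O[C@H](/C=C(\C)CC[C@@H](O)[C@]1(C)CCC(=O)O1)C/C(C)=C/CCc1ccoc1`) differs from compound 1 by acetyl in place of hydrogen on an oxygen on a saturated carbon with acetyl in place of hydrogen on an oxygen on a saturated carbon, which reads as hydroxy to acetoxy. The closest guide is the same exchange made at a different oxygen, with the step of a 2.0-fold lower number from compound 1 to compound 3 (0.30 log units; within the scatter) staying within the scatter. The large step of an at least 20-fold higher number from compound 1 to compound 2 (1.30 log units; beyond the scatter) replaces the furan-3-yl instead, so it does not bear on this change. In this assay no step beyond the scatter is therefore expected: the estimated step is a 1.5-fold lower number from compound 1 to compound 4 (0.19 log units; within the scatter) with a slight lean toward lower numbers. Compound 4 is estimated at 650 nM with an expected range of 200 nM to 2200 nM for repeated measurements.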

Compound 4, half-maximal inhibitory concentration: 2200 nM
Compound 4: middle estimate off by 3.4-fold (0.53 log units), on the low side; the measured number falls inside the stated range.
By their numbers in this assay, from the lowest: compounds 3 and 1 (each within the scatter of the next); then compound 4. At a limit, above all of these: compound 2.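

In this assay the exchange of hydrogen for acetyl on an oxygen on a saturated carbon whose other neighbours are saturated chain carbon gives a 2.2-fold higher number from compound 1 to compound 4 (0.34 log units; beyond the scatter) and so leaves the scatter, which the earlier acetyl exchange did not do. That earlier exchange, made at a different oxygen, gives a 2.0-fold lower number from compound 1 to compound 3 (0.30 log units; within the scatter) and stays within the scatter, so among these compounds the reading of hydroxy to acetoxy depends on which oxygen carries the acetyl, even though this modest step remains small beside an at least 20-fold higher number from compound 1 to compound 2 (1.30 log units; beyond the scatter) where the furan-3-yl is replaced. Nothing among the available measurements bears on why this oxygen differs from the other one.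

The compounds shown leave open whether the rise in the number belongs to acetyl itself or would also follow from another group on this oxygen, such as a methyl ether or a longer acyl chain like hexanoyl. They also leave open how an amine in place of this hydroxy would read, and what acetyl on both oxygens together would give.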